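A few compounds are considered here, and "the series" means these few. Any claim that something is new, unique, unknown or untested is made for them only; others in the source may bear on it.

In a functional assay (trachea) with Cavia porcellus as the target (on this read-out higher numbers stand for weaker inhibition and lower numbers for stronger inhibition), two numbers stand so far: compound 1 `Oc1nnc(-c2cccnc2)c2ccccc12` gives 10200 nM, and compound 2 `O=c1c2ccccc2c(-c2cccnc2)nn1C1CCCC1` gives 2750 nM, the lower of the two and beyond the scatter from compound 1. Compound 3 `CCOC(=O)Cn1nc(-c2cccnc2)c2ccccc2c1=O` differs from compound 2 on an aromatic nitrogen, with (ethoxycarbonyl)methyl in place of cyclopentyl on an aromatic nitrogen. Going by the values given here, no measured step covers this exchange, so the expectation rests on little. A modest move towards a higher number in this assay is expected, a 1.8-fold higher number from compound 2 to compound 3 (0.26 log units; within the scatter). Compound 3 is estimated at 5000 nM, with an expected range of 1500 nM to 16000 nM.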

Compound 3, half-maximal inhibitory concentration: 43700 nM
For compound 3 the middle estimate is 8.7-fold (0.94 log units) below the measured one; measured number above the stated range.
By their numbers in this assay, from the lowest: compound 2; then compound 1; then compound 3.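

In this assay, this position on the aromatic nitrogen responds strongly to the exchange of cyclopentyl for (ethoxycarbonyl)methyl, which gives a 16-fold higher number from compound 2 to compound 3 (1.20 log units; beyond the scatter) and so moves towards weaker inhibition. The step swaps a carbon-only ring for an open chain with two hydrogen-bond acceptors, and this single pair cannot separate losing the ring from gaining the acceptors. No supporting data bear on what lies behind the step.

Open, from the compounds shown here alone, is whether a plain pentyl chain would behave like cyclopentyl. Also open, going by these compounds, is how a carboxylic acid or an amine at the chain end would compare with the ethyl ester.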